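The compounds below may be only part of what the source reports. "The series", "measured", "known", "first", "only" and "open" are said of these compounds alone.

Measured so far:
compound 1 `N#Cc1ccc(CNc2ccc(-c3c(N)nc(N)nc3COCc3ccccc3)cc2)cc1`: 19 nM
compound 2 `COc1ccc(CNc2ccc(-c3c(N)nc(N)nc3COCc3ccccc3)cc2)cc1`: 90 nM

In a functional assay on CHOK cells for antagonist activity at growth hormone secretagogue receptor type 1 (Homo sapiens), read by calcium flux (on this read-out lower numbers stand for stronger inhibition and higher numbers for weaker inhibition), compound 2 stands at the higher of the two numbers; compound 1 sits at 19 nM below it. Compound 3 `CC(C)(C)CNc1ccc(-c2c(N)nc(N)nc2COCc2ccccc2)cc1` carries tert-butyl in place of 4-methoxyphenyl on a saturated chain carbon bound to a nitrogen on an aromatic ring. Among the measured compounds shown here, the only measured step, a 4.7-fold higher number from compound 1 to compound 2 (0.68 log units; beyond the scatter), exchanges one substituent on the aromatic ring and does not cover loss of that ring, so no measured step bears directly on this change. With an aromatic group removed, a modestly weaker result is expected: a 2.2-fold higher number from compound 2 to compound 3 (0.35 log units; beyond the scatter). Compound 3 is therefore estimated at 200 nM in this assay, within 60 nM to 700 nM.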

Compound 3, half-maximal inhibitory concentration: 700 nM
Estimate against measurement, compound 3: 3.5-fold (0.54 log units) below; the measured number falls inside the stated range.
By their numbers in this assay, from the lowest: compound 1; then compound 2; then compound 3.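

In this assay, the step of a 7.8-fold higher number from compound 2 to compound 3 (0.89 log units; beyond the scatter) shows that tert-butyl does not stand in for 4-methoxyphenyl at this place, and the step of a 37-fold higher number from compound 1 to compound 3 (1.57 log units; beyond the scatter) shows the same for 4-cyanophenyl. Among these compounds, both ring-bearing groups give lower numbers than the ring-free tert-butyl. No available evidence accounts for these steps.

Open, going by these compounds, is whether cyclohexyl at this place would read like the aromatic groups or like tert-butyl. Also open, on these data alone, is how an amine or a carboxylic acid on the aromatic ring would compare with cyano and methoxy.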